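The compounds below may be only part of what the source reports. "The series", "measured", "known", "first", "only" and "open" are said of these compounds alone.

In a functional assay (aorta) with Oryctolagus cuniculus as the target (a higher number here means a weaker inhibitor, a lower number a stronger inhibitor), compound 3 (`CCO/C(O)=C1\C(C)=NC(C)=C(C(=O)OCCCN2C(=O)c3ccccc3S2(=O)=O)C1c1ccccc1Cl`) gives 3.9 nM, the highest number among the measured compounds, with compound 2 (`CO/C(O)=C1\C(C)=NC(C)=C(C(=O)OCCCN2C(=O)c3ccccc3S2(=O)=O)C1c1ccccc1Cl`) at 1.8 nM. Compound 4 (`CC1=NC(C)=C(C(=O)OCCCN2C(=O)c3ccccc3S2(=O)=O)C(c2ccccc2Cl)/C1=C(\O)OCC1CCCCO1`) has oxan-2-yl in place of methyl on a saturated chain carbon bound to an oxygen on an unsaturated carbon. Going by the values given here, the only measured step at this place, a 2.2-fold higher number from compound 2 to compound 3 (0.34 log units; beyond the scatter), is modest and involves a much smaller group. Compound 1 (`CC1=NC(C)=C(C(=O)OCCCN2C(=O)c3ccccc3S2(=O)=O)C(c2ccccc2C(F)(F)F)/C1=C(\O)OCC1CCCCO1`), at 1.4 nM, also carries oxan-2-yl but differs from compound 4 elsewhere, so it is only a loose guide. A modest move to a lower number is therefore expected, a 1.6-fold lower number from compound 3 to compound 4 (0.19 log units; within the scatter). For compound 4 the estimated value is 2.5 nM, with an expected range of 1 nM to 6.5 nM.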

Compound 4, half-maximal inhibitory concentration: 7 nM
For compound 4 the middle estimate is 2.8-fold (0.45 log units) below the measured one; the whole stated range lies below it.
By their numbers in this assay, from the lowest: compounds 1 and 2 (each within the scatter of the next); then compounds 3 and 4 (each within the scatter of the next).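

In this assay, oxan-2-yl and methyl on a saturated chain carbon bound to an oxygen on an unsaturated carbon do not separate (a 1.8-fold higher number from compound 3 to compound 4 (0.25 log units; within the scatter)), while oxan-2-yl in place of hydrogen gives a real step (a 3.9-fold higher number from compound 2 to compound 4 (0.59 log units; beyond the scatter)) in the same direction as methyl in place of hydrogen. With oxan-2-yl held constant, chloro in place of trifluoromethyl on an aromatic carbon also gives a real step (a 5.0-fold higher number from compound 1 to compound 4 (0.70 log units; beyond the scatter)), so the low number of compound 1 does not follow from oxan-2-yl alone. No measurement here bears on the cause of these steps. Open, going by these compounds, are a longer unbranched chain or an amine on this chain carbon, and whether trifluoromethyl gives the same step when paired with methyl.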